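A halogen pair replaces the nitrile on the pendant phenyl

The source may hold more compounds than are shown below. What is called first, only, known or untested is meant among the compounds shown, and "the series" means these compounds.

Three compounds share a core in which an acetamidophenyl-piperidine is tethered by a three-carbon chain to a benzimidazole bearing an aryl group. Compound 1 `CC(=O)Nc1cccc(C2CCN(CCCn3c(-c4cccc(C(F)(F)F)c4)nc4ccccc43)CC2)c1` gives 30 nM in an assay for displacement of a labelled ligand from melanin-concentrating hormone receptor 1 (Homo sapiens), read by fluorescence (on this read-out lower numbers stand for stronger inhibition and higher numbers for weaker inhibition), compound 2 `CC(=O)Nc1cccc(C2CCN(CCCn3c(-c4ccc(Br)cc4)nc4ccccc43)CC2)c1` gives 5 nM, and compound 3 `CC(=O)Nc1cccc(C2CCN(CCCn3c(-c4ccc(C#N)cc4)nc4ccccc43)CC2)c1` gives 16 nM. Compound 3 thus holds the second highest number of the three, separated from compound 1 by a step within the scatter and from compound 2 by a step beyond it, a 3.2-fold higher number from compound 2 to compound 3 (0.51 log units; beyond the scatter).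

Compound 4 `CC(=O)Nc1cccc(C2CCN(CCCn3c(-c4ccc(F)cc4Cl)nc4ccccc43)CC2)c1` carries the change (2-chloro-4-fluorophenyl in place of 4-cyanophenyl on an aromatic carbon). For the measured compounds named here, the steps that bear on it are a 3.2-fold higher number from compound 2 to compound 3 (0.51 log units; beyond the scatter) and a 6.0-fold lower number from compound 1 to compound 2 (0.78 log units; beyond the scatter): the halogen-bearing ring of compound 2 gave lower numbers than either the nitrile or the trifluoromethyl. A ring carrying chloro and fluoro is therefore expected to move compound 4 toward lower numbers in this assay , with an expected step of a 2.0-fold lower number from compound 3 to compound 4 (0.30 log units; within the scatter). Compound 4 is estimated at 8 nM, in a range from 3 nM to 25 nM.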

Compound 4, half-maximal inhibitory concentration: 4 nM
Estimate against measurement, compound 4: 2.0-fold (0.30 log units) above, within the range that was stated.
By their numbers in this assay, from the lowest: compounds 4 and 2 (each within the scatter of the next); then compounds 3 and 1 (each within the scatter of the next).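

In this assay, the group on the aromatic carbon between two ring nitrogen atoms can carry two halogens, including a 2-chloro substituent, which no earlier ring had, and the number still falls, with a 4.0-fold lower number from compound 3 to compound 4 (0.60 log units; beyond the scatter) and a 7.5-fold lower number from compound 1 to compound 4 (0.88 log units; beyond the scatter). The change from the single bromo, a 1.3-fold lower number from compound 2 to compound 4 (0.10 log units; within the scatter), does not separate the two halogen-bearing rings, so a bromo at the 4-position is not the only halogen pattern linked to numbers this low. Nothing measured here bears on the cause of these steps.

The compounds shown leave open whether a ring with the chloro alone or the fluoro alone would give a similar number to compound 4. They also leave open how a ring bearing an amine or a carboxylic acid would compare with these halogen-bearing rings.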